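Removing the bromine from the benzyl ring of compound 2

A few compounds are considered here, and "the series" means these few. Any claim that something is new, unique, unknown or untested is made for them only; others in the source may bear on it.

Measured compounds:
compound 1 `COC(=O)c1ccc(NCc2cncn2Cc2cccc(C)c2)cc1-c1ccccc1`: > 10000 nM
compound 2 `COC(=O)c1ccc(NCc2cncn2Cc2cccc(Br)c2)cc1-c1ccccc1`: > 10000 nM
compound 3 `CN(C)C(=O)c1ccc(NCc2cncn2Cc2ccc(-c3ccccc3)cc2)cc1-c1ccccc1`: > 1000 nM

In a toxicity assay on NIH3T3 cells (Mus musculus) for cytotoxicity, read by resazurin assay (on this read-out lower numbers stand for an effect already at smaller amounts and higher numbers for an effect only at larger amounts of compound), compound 1 gives > 10000 nM, which is a limit of the assay and not a number. Compound 2 likewise gives only a limit in this assay, namely > 10000 nM. Compound 3 gives > 1000 nM in this assay, again a limit. All three values therefore sit at limits: the limit of > 10000 nM in this assay, at which 2 of the 3 values shown sit, and (the limit of > 1000 nM in this assay, at which 1 of the 3 values shown sits). The step that the two limits leave unreadable from compound 1 to compound 2 cannot be sized, since both ends are limits.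

Compound 2 thus stands at the top of the measured range with no number of its own. Compound 4 `COC(=O)c1ccc(NCc2cncn2Cc2ccccc2)cc1-c1ccccc1` differs from compound 2 by hydrogen in place of bromo on an aromatic carbon. Within the data shown here, the only measured step at the same position is a step that the two limits leave unreadable from compound 1 to compound 2, which is unreadable, and no measured step in this assay shows a change between two numbers at all. The series gives no ground to expect compound 4 to move off the limit. The step that the limit leaves unreadable from compound 2 to compound 4 is expected to be none beyond the scatter. Compound 4 is estimated at 20000 nM in this assay, with a range from 5000 nM to 100000 nM, and is expected most likely to be reported again only as a limit.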

Compound 4, half-maximal effective concentration: > 1000 nM
Compound 4: no number, only a limit; the forecaster's own chance of this, stated with the estimate: 85%; the middle value is on the limit's open side.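

Compound 4, like compound 1 and compound 2, carries only a limit of the assay and not a number in this assay, so no step among these three compounds can be read. The compounds shown leave open whether any change on the benzyl ring would give a measured number in this assay.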